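A few compounds are considered here, and "the series" means these few. Any claim that something is new, unique, unknown or untested is made for them only; others in the source may bear on it.

Compound 1 has the structure `COc1ccc(NC(=O)Nc2cc(C)nc3ccccc23)cc1`. In an ADME assay on HEK293 cells (Homo sapiens) for cytotoxicity, with a stated time of 72 h (a lower number here means that less compound is needed, a higher number that more compound is needed for the effect), compound 1 gives a value of > 25000 nM, which is a limit of the assay rather than a number.
Compound 2 has the structure `Cc1ccc(NC(=O)Nc2cc(C)nc3ccccc23)cc1`. In this assay compound 2 gives > 25000 nM, again a limit.
Compound 3 has the structure `Cc1cc(NC(=O)Nc2ccc(O)cc2)c2ccccc2n1`. In this assay compound 3 gives > 25000 nM, also a limit.

Compound 3 therefore stands at the same limit as its two neighbours, with no number of its own: the limit of > 25000 nM in this assay, at which 3 of the 3 values shown sit. The three single-point changes among these compounds, a step that the two limits leave unreadable from compound 1 to compound 2, a step that the two limits leave unreadable from compound 1 to compound 3 and a step that the two limits leave unreadable from compound 2 to compound 3, all end in limits on both sides, so none of them can be read as a step of any size or direction. The next compound, compound 4, has the structure `COC(=O)c1ccc(NC(=O)Nc2cc(C)nc3ccccc23)cc1` and differs from compound 3 as follows: methoxycarbonyl in place of hydroxy on an aromatic carbon. Among the measured compounds shown here, no measured step touches a methoxycarbonyl group, and the steps that do exist are unreadable, so there is no basis for expecting a step in this assay beyond the scatter in either direction. The estimate for compound 4 is that it will again sit at the limit, at about 30000 nM with a range from 10000 nM to 100000 nM; the step this implies, a step that the limit leaves unreadable from compound 3 to compound 4, is expected to be nothing beyond the scatter.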

Compound 4, half-maximal effective concentration: 15000 nM
Estimate against measurement, compound 4: 2.0-fold (0.30 log units) above; the range from low to high includes it.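

In this assay compound 4 gives 15000 nM, a real number rather than a limit, so this place on the ring, para to a large group, can carry a group that brings the read-out within the range of the assay. Methoxycarbonyl in place of hydroxy gives an at least 1.6-fold lower number from compound 3 to compound 4 (0.22 log units; that floor lies within the scatter), in place of methyl it gives an at least 1.6-fold lower number from compound 2 to compound 4 (0.22 log units; that floor lies within the scatter), and in place of methoxy it gives an at least 1.6-fold lower number from compound 1 to compound 4 (0.22 log units; that floor lies within the scatter). Each of these is only a floor, so the true size of the step is unknown and could be larger, while the earlier steps among compound 1, compound 2 and compound 3 still cannot be read, and compound 4 remains the only one with a number of its own: the limit of > 25000 nM in this assay, at which 3 of the 4 values shown sit.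

As far as these compounds go, it remains open how far compound 4 truly lies from its neighbours, since none of them has a number to set against it. From the compounds shown here alone, it is also open whether other groups at this place, such as a carboxylic acid, an amine or a longer chain, would give a number or stay at the limit.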